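Two amine variants measured, a third awaiting its number

The compounds below may be only part of what the source reports. "The series", "measured", "known", "first", "only" and "open" are said of these compounds alone.

Compound 1: `O=C1CCC(N2C(=O)c3cccc(Nc4ccccn4)c3C2=O)C(=O)N1` — 1%
Compound 2: `Cc1ccccc1Nc1ccc2c(c1)C(=O)N(C1CCC(=O)NC1=O)C2=O` — 2%

In an assay on FRT-Jurkat cells for inhibition of nuclear factor NF-kappa-B complex (Homo sapiens), read by flow cytometry, with a stated time of 24 h, tested at 10 uM (a higher number here means more inhibition at the concentration tested (going by the name of the read-out), a lower number less inhibition), compound 1 gives 1% and compound 2 gives 2%. Among the measured compounds shown here, the two numbers lie within the scatter of each other, so on the numbers so far compound 1 is not told apart from compound 2: both sit at the bottom of the scale, with essentially no inhibition at the concentration tested. For the measured compounds named here, no pair of measured compounds differs in one place only, so no measured step is available to guide the next compound.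

Compound 3 is `CCCc1ccc(Nc2cccc3c2C(=O)N(C2CCC(=O)NC2=O)C3=O)cc1`. It differs from compound 1 as 4-propylphenyl in place of pyridin-2-yl on a nitrogen on an aromatic ring. Nothing measured shows what a change at this nitrogen does, since compound 2 varies at another place on the shared core. Given compound 1 at 1%, the expected step is a number 4 percentage points higher from compound 1 to compound 3 (within the scatter), none beyond the scatter in either direction. Compound 3 is therefore estimated at 5%, with a range from -10% to 25%. A limit rather than a number is not expected from this read-out.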

Compound 3, a percentage reported as inhibition, at one concentration (the size of the read-out at that concentration, not a potency): 23%
Estimate against measurement, compound 3: 18 percentage points below; the measured number falls inside the stated range.
By their numbers in this assay, from the lowest: compounds 1 and 2 (each within the scatter of the next); then compound 3.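

In this assay, 4-propylphenyl in place of pyridin-2-yl on a nitrogen on an aromatic ring gives a number 22 percentage points higher from compound 1 to compound 3 (beyond the scatter), which shows that the group on this nitrogen can move the read-out, something compounds 1 and 2 could not show. The swap removes the ring's hetero atom and its hydrogen-bond acceptor and also brings in the propyl chain, so this single step cannot assign the gain to either part of the change. Nothing available bears on why the number rises, and the explanation stays unassigned.

Open, from the compounds shown here alone, is which part of the change carries the step: plain phenyl would separate the carbon-only ring from the propyl chain, while 4-butylphenyl or a carboxylic acid in place of the propyl chain would test how the number responds to the group at the end of the ring. Also open, going by these compounds, is how compound 3 ranks by potency, since a percentage at one concentration is the size of the read-out and not a potency, and whether the step carries over to other groups on this nitrogen.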